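Methyl in place of phenyl on the core of compound 1

A few compounds are considered here, and "the series" means these few. Any claim that something is new, unique, unknown or untested is made for them only; others in the source may bear on it.

In a functional assay on HCT-116 cells (Homo sapiens) for inhibition, read by colorimetric assay, with a stated time of 3 days (on this read-out higher numbers stand for weaker inhibition and lower numbers for stronger inhibition), compound 1 (`O=C(CCCCCCNC(=O)C(O)(O)C(F)(F)F)Nc1nc(-c2ccccc2)c(-c2ccccc2)s1`) gives 29900 nM and holds the higher of the two numeric values available. Compound 2 (`O=C(CCCCCCNC(=O)C(O)(O)C(F)(F)F)Nc1cccc2ccccc12`) gives 6480 nM as a lower number, and that gap lies beyond the scatter. Compound 3 (`O=C(CCCCNC(=O)c1cc(=O)c(O)co1)Nc1ccccc1`) is reported in this assay only as a limit (> 100000 nM) and gives no number.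

The next compound is compound 4 (`Cc1nc(NC(=O)CCCCCCNC(=O)C(O)(O)C(F)(F)F)sc1-c1ccccc1`), which has methyl in place of phenyl on an aromatic carbon of a five-membered aromatic ring with 1 nitrogen and 1 sulfur, next to the ring nitrogen and next to the ring atom that bears a phenyl group (methyl in place of phenyl on an aromatic carbon). Going by the values given here, no measured step between closely matched compounds covers this change, so the expectation rests on little. A lower number than that of compound 1 does occur in this small set, as compound 2 at 6480 nM shows, so a modest move toward a lower number is expected, near the edge of the scatter or a little past it. The step expected in this assay is a 2.1-fold lower number from compound 1 to compound 4 (0.33 log units; beyond the scatter) by this estimate. For compound 4 the estimated value is 14000 nM with an expected range from 5000 nM to 50000 nM as the working figure.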

Compound 4, half-maximal inhibitory concentration: 10100 nM
Beside the measured number, compound 4's estimate is 1.4-fold (0.14 log units) above it; measured number inside the range.
By their numbers in this assay, from the lowest: compounds 2 and 4 (each within the scatter of the next); then compound 1. At a limit, above all of these: compound 3.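

Notes on the position: in this assay, the first matched step of the series is a 3.0-fold lower number from compound 1 to compound 4 (0.47 log units; beyond the scatter), and it belongs to the swap of phenyl for methyl on an aromatic carbon of a five-membered aromatic ring with 1 nitrogen and 1 sulfur. This position therefore does not depend on the phenyl to hold a measurable number in this assay: methyl, with 1 heavy atom in place of 6, gives a lower number even though a six-membered aromatic ring of carbon only leaves, while the phenyl on the neighbouring ring atom stays in both compounds. No measured property at hand bears on why the number moves with this change.

Going by these compounds, whether the number keeps falling with a hydrogen at this position, or holds with an ethyl or an amine, stays open, so a single step cannot yet be read as a trend with group size. Going by these compounds alone, also open is whether the same swap gives a step of similar size when a shorter chain replaces the one shared by compound 1 and compound 4.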